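This account rests on a few compounds, and the source may have more. Where it says the series, first, only, none or still open, it means among the compounds named here.

Measured so far:
compound 1 `COC1(c2cc(F)cc(OCc3ccc(-n4ccnc4C)cc3)c2)CCOCC1`: 60 nM
compound 2 `CNC(=O)C1(c2cc(F)cc(OCc3ccc(-n4ccnc4C)cc3)c2)CCOCC1`: 280 nM
compound 3 `Cc1nccn1-c1ccc(COc2cc(F)cc(C3(C(=O)N(C)C)CCOCC3)c2)cc1`: 810 nM

In an assay on blood for inhibition of Polyunsaturated fatty acid 5-lipoxygenase (Homo sapiens) (a higher number here means a weaker inhibitor, a lower number a stronger inhibitor), compound 2 gives the second highest of the three numbers: a 4.7-fold higher number from compound 1 to compound 2 (0.67 log units; beyond the scatter) and a 2.9-fold higher number from compound 2 to compound 3 (0.46 log units; beyond the scatter), both beyond the scatter. Compound 4 `Cc1nccn1-c1ccc(COc2cc(F)cc(C3(S(C)(=O)=O)CCOCC3)c2)cc1` differs from compound 2 in one place: methylsulfonyl in place of methylcarbamoyl on a saturated ring carbon. The measured steps that touch this ring carbon are a 4.7-fold higher number from compound 1 to compound 2 (0.67 log units; beyond the scatter) and a 14-fold higher number from compound 1 to compound 3 (1.13 log units; beyond the scatter), each raising the number once the methoxy is gone, while a 2.9-fold higher number from compound 2 to compound 3 (0.46 log units; beyond the scatter) separates the two amides. Going by the values given here, no measured step exchanges an amide for a sulfonyl, so no firm direction follows; a step of about a 1.4-fold higher number from compound 2 to compound 4 (0.15 log units; within the scatter) is expected, within the scatter. Compound 4 is therefore estimated at 400 nM, with a range of 120 nM to 1400 nM.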

Compound 4, half-maximal inhibitory concentration: > 1000 nM
Compound 4 ended at the assay's limit; the forecaster's own chance of this, stated with the estimate: 3%; middle value at least 2.5-fold (0.39 log units) from the limit.
By their numbers in this assay, from the lowest: compound 1; then compound 2; then compound 3. At a limit, above all of these: compound 4.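

In this assay compound 4 stands at a limit of the assay, not at a number: the limit of > 1000 nM in this assay, at which 1 of the 4 values shown sits. Methylsulfonyl on this saturated ring carbon gives a weaker inhibitor than methylcarbamoyl, with an at least 3.5-fold higher number from compound 2 to compound 4 (0.55 log units; beyond the scatter), and than methoxy, with an at least 16-fold higher number from compound 1 to compound 4 (1.22 log units; beyond the scatter). Its order against dimethylcarbamoyl stays unsettled, as an at least 1.2-fold higher number from compound 3 to compound 4 (0.09 log units; that floor lies within the scatter) gives only a floor, and that floor lies within the scatter.

Still open, as far as these compounds go, is how an amine or a carboxylic acid on this ring carbon would compare with methoxy. Also open, from the compounds shown here alone, is whether ethoxy, a longer chain, would keep the number of compound 1.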